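This account rests on a few compounds, and the source may have more. Where it says the series, first, only, none or still open, it means among the compounds named here.

Compound 1 `O=C(Nc1cccc(-n2cc(-c3ccncc3)c(-c3ccc(Cl)c(O)c3)n2)c1)Nc1cccc(C(F)(F)F)c1`: 1330 nM
Compound 2 `O=C(Nc1cccc(-n2cc(-c3ccncc3)c(-c3ccc(Cl)c(O)c3)n2)c1)Nc1cc(C(F)(F)F)cc(C(F)(F)F)c1`: 506 nM

Two compounds share one core and differ only in the groups on the outer ring of the urea. In a functional assay on KM12 cells (Homo sapiens) for inhibition, read by sulforhodamine B assay, with a stated time of 48 h (on this read-out lower numbers stand for stronger inhibition of growth and higher numbers for weaker inhibition of growth), compound 1 gives 1330 nM, the highest of the two numbers, and so the weaker of the two at slowing cell growth. Among the compounds with values here, compound 2 sits nearest with 506 nM, and the single step of a 2.6-fold lower number from compound 1 to compound 2 (0.42 log units; beyond the scatter) is a change on that outer ring.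

Compound 3 `O=C(Nc1cccc(-n2cc(-c3ccncc3)c(-c3ccc(Cl)c(O)c3)n2)c1)Nc1ccc(Cl)c(C(F)(F)F)c1` has not been tested. It arises from compound 1 by a change on the same outer ring: chloro in place of hydrogen on an aromatic carbon. Within the data shown here, the only measured step that speaks to it is the one from compound 1 to compound 2, where adding a second group to this ring gave a modest gain. A chloro group entering at the place described is a comparable addition, so a modest step in the same direction is expected, though no measurement of a chloro group here exists. Compound 3 is therefore expected to show a 2.0-fold lower number from compound 1 to compound 3 (0.31 log units; beyond the scatter), landing near 650 nM, within a range of 250 nM to 1700 nM.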

Compound 3, concentration for 50% growth inhibition: 1000 nM
Estimate against measurement, compound 3: 1.5-fold (0.19 log units) below, and the stated range covers the measured number.
By their numbers in this assay, from the lowest: compounds 2, 3 and 1 (each within the scatter of the next, the first and the last beyond it).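

Chloro in place of hydrogen on the outer ring gives a 1.3-fold lower number from compound 1 to compound 3 (0.12 log units; within the scatter) in this assay, so at this position, ortho to a trifluoromethyl group and para to a large group, the new group leaves the number no different from that of compound 1 by any margin the assay can resolve. The earlier pair alone could suggest that any second group on this ring helps, yet only the second trifluoromethyl group of compound 2, with a 2.6-fold lower number from compound 1 to compound 2 (0.42 log units; beyond the scatter), gives a step beyond the scatter, while the chloro group of compound 3 does not. Nothing measured here accounts for the difference between these two additions.

Going by these compounds, it remains open whether another group at this same place, such as a methoxy group, an amine or a carboxylic acid, would move the number beyond the scatter, and whether chloro would behave the same way elsewhere on the ring. On these data alone, it is also open what happens when the trifluoromethyl group of compound 1 is itself replaced, for instance by a nitrile.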